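Removing the fluorine from a 4-fluorophenyl ester

This account rests on a few compounds, and the source may have more. Where it says the series, first, only, none or still open, it means among the compounds named here.

Measured in a functional assay on SK-BR-3 cells (Homo sapiens) for antiproliferative activity, read by MTT assay, with a stated time of 72 h; a higher number here means a weaker inhibitor, a lower number a stronger inhibitor:
Compound 1 `C/C=C1/[C@H](O[C@@H]2O[C@H](CO)[C@@H](O)[C@H](O)[C@H]2O)OC=C(C(=O)OC)[C@H]1CC(=O)OCCCc1ccc(OC)c(OC)c1`: > 20000 nM (a limit)
Compound 2 `C/C=C1/[C@H](O[C@@H]2O[C@H](CO)[C@@H](O)[C@H](O)[C@H]2O)OC=C(C(=O)OC)[C@H]1CC(=O)OCCC1CCCCC1`: 2000 nM
Compound 3 `C/C=C1/[C@H](O[C@@H]2O[C@H](CO)[C@@H](O)[C@H](O)[C@H]2O)OC=C(C(=O)OC)[C@H]1CC(=O)OCCc1ccc(F)cc1`: > 20000 nM (a limit)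

Compound 3 gives > 20000 nM as a limit and not as a number. It therefore stands at the limit of > 20000 nM in this assay, at which 2 of the 3 values shown sit, and has no readable potency. Compound 2 alone gives a number in this series.

The next structure is compound 4 `C/C=C1/[C@H](O[C@@H]2O[C@H](CO)[C@@H](O)[C@H](O)[C@H]2O)OC=C(C(=O)OC)[C@H]1CC(=O)OCCc1ccccc1`, which carries hydrogen in place of fluoro on an aromatic carbon, para to a large group hydrogen in place of fluoro on an aromatic carbon and so bears a phenethyl ester.

Within the data shown here, no measured step makes this change. The nearest steps replace the whole ring group. Going to the 4-fluorophenyl group gave an at least 10-fold higher number from compound 2 to compound 3 (1.00 log units; beyond the scatter) and going to the cyclohexyl group gave an at least 10-fold lower number from compound 1 to compound 2 (1.00 log units; beyond the scatter) in the same assay. The remaining step is a step that the two limits leave unreadable from compound 1 to compound 3 and says nothing on size.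

Compound 4 keeps an aromatic ring, like compound 3 in an at least 10-fold higher number from compound 2 to compound 3 (1.00 log units; beyond the scatter), and so no step beyond the scatter is expected in this assay, with another limit quite likely. The estimated step is a number no higher from compound 3 to compound 4 (the limit leaves the size open) in this reading. For compound 4 the expected value is 20000 nM with an estimated range from 7000 nM to 50000 nM in this assay.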

Compound 4, half-maximal inhibitory concentration: 11000 nM
Estimate against measurement, compound 4: 1.8-fold (0.26 log units) above; the measured number falls inside the stated range.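

In this assay compound 4 gives a readable number and so does not sit with the two compounds held at the limit, which shows that an aromatic ring at this end of the ester does not by itself mean a limit: the limit of > 20000 nM in this assay, at which 2 of the 4 values shown sit. Hydrogen in place of fluoro gives an at least 1.8-fold lower number from compound 3 to compound 4 (0.25 log units; that floor lies within the scatter), and phenyl in place of 3,4-dimethoxybenzyl gives an at least 1.8-fold lower number from compound 1 to compound 4 (0.25 log units; that floor lies within the scatter), so neither step on its own establishes a real gain. Phenyl in place of cyclohexyl now gives the first comparison in this series between two numbers and not a limit, with a 5.5-fold higher number from compound 2 to compound 4 (0.74 log units; beyond the scatter), so the cost of the aromatic ring can be sized for the first time.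

The compounds shown leave open how large the effect of removing the fluorine really is, and whether a chloro, methoxy or hydroxyl group on that aromatic carbon would read differently from fluoro or hydrogen. They also do not tell how a longer chain, or an amine in place of the ring, would read in this assay.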